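Swapping the Amine Tail of Compound 2

The source may report more compounds than this note shows. Statements on the series, on what has been measured and on what is new or still open speak of the compounds shown alone.

Compound 2 `CCN(Cc1ccc(-c2ccnc3ccc(-c4cnc(OC)c(NS(=O)(=O)c5ccc(F)cc5F)c4)cc23)cc1)C1CCCCC1` gives 20.2 nM in a functional assay on A549 cells (Homo sapiens) for cytotoxicity, read by MTT assay, with a stated time of 72 h (on this read-out lower numbers stand for stronger inhibition and higher numbers for weaker inhibition), the lowest of the two numbers measured, while compound 1 `COc1ncc(-c2ccc3nccc(-c4ccc(C)cc4)c3c2)cc1NS(=O)(=O)c1ccc(F)cc1F` gives 1240 nM. Compound 3 `CNCCN(C)Cc1ccc(-c2ccnc3ccc(-c4cnc(OC)c(NS(=O)(=O)c5ccc(F)cc5F)c4)cc23)cc1` alters the very group whose addition drove that difference: methyl(2-(methylamino)ethyl)amino in place of cyclohexyl(ethyl)amino on a saturated chain carbon bound to an aromatic carbon. Among the compounds with values here, the only step measured so far, a 61-fold lower number from compound 1 to compound 2 (1.79 log units; beyond the scatter), shows that this position strongly affects the read-out, but no measured step shows how exchanging one amine for another there behaves. A moderate rise in this assay is therefore expected, a 3.0-fold higher number from compound 2 to compound 3 (0.47 log units; beyond the scatter). Compound 3 is estimated at 60 nM, between 15 nM and 250 nM.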

Compound 3, half-maximal inhibitory concentration: 13 nM
Estimate against measurement, compound 3: 4.6-fold (0.66 log units) above; the measured number lies below the stated range.
By their numbers in this assay, from the lowest: compounds 3 and 2 (each within the scatter of the next); then compound 1.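

In this assay, the step is a 1.6-fold lower number from compound 2 to compound 3 (0.19 log units; within the scatter), so compound 2 and compound 3 cannot be told apart, even though an open chain with no ring replaces the cyclohexyl-bearing amine. With a 95-fold lower number from compound 1 to compound 3 (1.98 log units; beyond the scatter), a second, quite different amine in place of hydrogen also gives a large step, so among these compounds the large step does not depend on the cyclohexyl ring. The data offer no measured explanation for this result.

From the compounds shown here alone, whether a smaller dimethylamino group, a morpholine ring or a carboxylic acid on this carbon would give a similar number remains open.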